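The source may hold more compounds than are shown below. What is called first, only, known or untested is meant among the compounds shown, and "the series" means these compounds.

Measured so far in a functional assay on HL-60 cells (Homo sapiens) for antiproliferative activity; a lower number here means a stronger inhibitor, a higher number a weaker inhibitor:
compound 1 (`COc1cc(/C=C/c2cc(OC)c(O)c(OC)c2)cc(OC)c1`): 20000 nM
compound 2 (`COc1cc(OC)cc(-c2ccccc2-c2ccc(O)cc2)c1`): 5000 nM

Of these two, compound 2 holds the lower number and so stands as the stronger inhibitor in this assay. The gap between compound 2 and compound 1 lies beyond the usual scatter of repeated measurements. Only these two values are in hand, and they say little about what any single change does.

The next compound to be tested is compound 3 (`COc1ccc(-c2ccccc2-c2cc(OC)cc(OC)c2)cc1`). It differs from compound 2 in one place (methyl in place of hydrogen on an oxygen on an aromatic ring): methyl in place of hydrogen on an oxygen on an aromatic ring, so that 4-hydroxyphenyl becomes 4-methoxyphenyl. Among the measured compounds shown here, no measured pair in this small set shows this change, so its size has to be estimated, and the only anchor is compound 2 at 5000 nM in this series. The expected change (a 1.3-fold lower number from compound 2 to compound 3 (0.10 log units; within the scatter)) is a small one, slightly toward a lower number and not beyond the scatter, though with real uncertainty in either direction. For compound 3 the estimated value is 4000 nM (expected range 800 nM to 20000 nM).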

Compound 3, half-maximal inhibitory concentration: 7000 nM
The estimate for compound 3 lay 1.8-fold (0.24 log units) below the measured number; the measured number falls inside the stated range.
By their numbers in this assay, from the lowest: compounds 2 and 3 (each within the scatter of the next); then compound 1.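

In this assay, among the compounds shown here, methyl in place of hydrogen on the oxygen of the 4-hydroxyphenyl group gives a 1.4-fold higher number from compound 2 to compound 3 (0.15 log units; within the scatter), the first step in this set that isolates a single change. At this position, then, the hydroxy hydrogen of compound 2 is not required to keep the activity at this level, and this assay does not tell 4-methoxyphenyl apart from 4-hydroxyphenyl. No supporting data are available to explain this result, so the step stands as an observation only.

What the compounds shown leave open is whether this tolerance extends beyond a single methyl, for instance to an ethoxy or benzyloxy group on the same oxygen, or to an amine or a fluorine in place of the hydroxy group. They also leave open whether the same change would be as small elsewhere, such as on the hydroxy group of compound 1, whose surroundings differ from those in compound 2.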